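The source may hold more compounds than are shown below. What is called first, only, known or untested is meant among the compounds shown, and "the series" means these compounds.

Measured in a functional assay on HCT-8 cells (Homo sapiens) for antiproliferative activity, read by MTT assay, with a stated time of 48 h; on this read-out lower numbers stand for stronger inhibition and higher numbers for weaker inhibition:
- compound 1 `COc1ccc2c(/C=C/C(=O)c3cc(OC)c(OC)c(SC)c3)c[nH]c2c1`: 138 nM
- compound 2 `COc1cc(C(=O)/C=C/c2c[nH]c3ccccc23)cc(SC)c1OC`: 167 nM
- compound 3 `COc1ccc2c(/C=C/C(=O)c3cc(OC)c(OC)c(SC)c3)cn(C)c2c1`: 157 nM

Compound 1 stands level with the other two within the scatter: a 1.2-fold higher number from compound 1 to compound 2 (0.08 log units; within the scatter), and a 1.1-fold higher number from compound 1 to compound 3 (0.06 log units; within the scatter).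

Compound 4 `COc1ccc2c(/C=C/C(=O)c3cc(OC)c(OC)c([Se]C)c3)c[nH]c2c1` carries a group of 2 heavy atoms (1 carbon, 1 selenium; no ring) in place of a group of 2 heavy atoms (1 carbon, 1 sulfur; no ring), on an aromatic carbon: methylsulfanyl leaves, and a group of 1 carbon and 1 selenium enters on the same aromatic carbon, ortho to a methoxy group.

Within the data shown here, neither measured step touches this group, and no measured compound contains selenium, so the evidence is indirect. Both steps, a 1.2-fold higher number from compound 1 to compound 2 (0.08 log units; within the scatter) and a 1.1-fold higher number from compound 1 to compound 3 (0.06 log units; within the scatter), stayed within the scatter, so no step beyond the scatter is expected in this assay.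

The expected change is a 1.0-fold lower number from compound 1 to compound 4 (0.01 log units; within the scatter).

For compound 4 the estimate is 135 nM, with an expected range of 55 nM to 340 nM.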

Compound 4, half-maximal inhibitory concentration: 78 nM
Estimate against measurement, compound 4: 1.7-fold (0.24 log units) above; the range from low to high includes it.
By their numbers in this assay, from the lowest: compounds 4, 1, 3 and 2 (each within the scatter of the next, the first and the last beyond it).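

In this assay, among these compounds, the aromatic carbon ortho to a methoxy group, untouched by the earlier steps, now has a measured exchange: the group of 1 carbon and 1 selenium in place of methylsulfanyl gives a 1.8-fold lower number from compound 1 to compound 4 (0.25 log units; within the scatter). This position therefore accepts selenium in place of sulfur, with the number staying level with that of compound 1. Nothing measured here accounts for the result.

Still open, going by these compounds, is whether a longer chain, a hydroxyl or an amine on this carbon would keep the number. Also open, on these data alone, is whether the same exchange reads alike on the cores of compound 2 and compound 3.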